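Urea to unsubstituted benzamide on the shared core

The source may report more compounds than this note shows. Statements on the series, on what has been measured and on what is new or still open speak of the compounds shown alone.

Three compounds of the series have numbers in a functional assay on A498 cells (Homo sapiens) for inhibition, read by sulforhodamine B assay, with a stated time of 48 h; on this read-out lower numbers stand for stronger inhibition and higher numbers for weaker inhibition. Compound 1 `COc1cc(-c2nn(-c3cccc(NC(=O)c4cccc(C(F)(F)F)c4)c3)cc2-c2ccncc2)ccc1Cl` gives 690 nM. Compound 2 `COc1cc(-c2nn(-c3cccc(NC(=O)Nc4cccc(C(F)(F)F)c4)c3)cc2-c2ccncc2)ccc1Cl` gives 960 nM. Compound 3 `COc1cc(-c2nn(-c3cccc(NC(=O)Nc4ccc(Cl)c(C(F)(F)F)c4)c3)cc2-c2ccncc2)ccc1Cl` gives 840 nM, which is the second highest of the three, nearest compound 2 and furthest from compound 1; both gaps lie within the scatter, so the three compounds are not distinguished here. The two steps that touch the carbonyl carbon, a 1.4-fold higher number from compound 1 to compound 2 (0.14 log units; within the scatter) and a 1.2-fold higher number from compound 1 to compound 3 (0.09 log units; within the scatter), are both within the scatter, as is a 1.1-fold lower number from compound 2 to compound 3 (0.06 log units; within the scatter).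

Compound 4 `COc1cc(-c2nn(-c3cccc(NC(=O)c4ccccc4)c3)cc2-c2ccncc2)ccc1Cl` is not yet measured. The change from compound 3 is phenyl in place of (4-chloro-3-(trifluoromethyl)phenyl)amino on a carbonyl carbon. Going by the values given here, its amide-for-urea part is covered by the step from compound 1 to compound 3, read backwards, which was small; the loss of the trifluoromethyl and chloro substituents has no direct precedent among the measured compounds. The expectation is therefore a step of a 1.2-fold higher number from compound 3 to compound 4 (0.08 log units; within the scatter) in this assay, not clearly beyond the scatter. Compound 4 is estimated at 1000 nM, with a range from 400 nM to 2500 nM.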

Compound 4, half-maximal inhibitory concentration: 360 nM
The estimate for compound 4 lay 2.8-fold (0.44 log units) above the measured number; measured number outside the range, below it.
By their numbers in this assay, from the lowest: compounds 4, 1, 3 and 2 (each within the scatter of the next, the first and the last beyond it).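

In this assay, going by these compounds alone, phenyl on the carbonyl carbon stands apart from both urea groups, with a 2.3-fold lower number from compound 3 to compound 4 (0.37 log units; beyond the scatter) and a 2.7-fold lower number from compound 2 to compound 4 (0.43 log units; beyond the scatter) as modest steps, a separation that the earlier compounds at this position did not show among themselves. With the amide kept, hydrogen in place of trifluoromethyl on an aromatic carbon gives a 1.9-fold lower number from compound 1 to compound 4 (0.28 log units; within the scatter) and so does not separate that pair, which means the steps from the ureas cannot be assigned to the amide link or to the bare ring alone. Nothing on hand explains these steps.

Open, as far as these compounds go, is whether a plain phenylamino group on the carbonyl carbon, the urea without ring substituents, would read like compound 4 or like the other ureas. Also open, from the compounds shown here alone, is how the benzamide ring tolerates a single methoxy, an amine or a carboxylic acid in place of hydrogen.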